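This account rests on a few compounds, and the source may have more. Where it says the series, first, only, none or still open, it means among the compounds named here.

Measured in a functional assay on MDA-MB-231 cells (Homo sapiens) for antiproliferative activity, read by CCK-8 assay, with a stated time of 72 h; on this read-out lower numbers stand for stronger inhibition and higher numbers for weaker inhibition:
compound 1 `O=C(Nc1cccc(-c2oc3cc(-c4ccc(F)cc4)ccc3c(=O)c2O)c1)c1ccc(Cl)cc1`, 12800 nM
compound 2 `O=C(Nc1cccc(-c2oc3cc(-c4ccc(F)cc4)ccc3c(=O)c2O)c1)c1ccc(C(F)(F)F)cc1`, 29400 nM
compound 3 `O=C(Nc1cccc(-c2oc3cc(-c4ccc(F)cc4)ccc3c(=O)c2O)c1)c1ccc(Br)cc1`, 24900 nM

Compound 3 stands second highest of the three numbers. Its gaps to the others, a 1.2-fold lower number from compound 2 to compound 3 (0.07 log units; within the scatter) and a 1.9-fold higher number from compound 1 to compound 3 (0.29 log units; within the scatter), both lie within the scatter, so nothing separates it from either neighbour; only a 2.3-fold higher number from compound 1 to compound 2 (0.36 log units; beyond the scatter) reaches beyond the scatter, and that modestly.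

Compound 4 `O=C(Nc1cccc(-c2oc3cc(-c4ccc(F)cc4)ccc3c(=O)c2O)c1)c1cc(F)cc(F)c1` carries the change (3,5-difluorophenyl in place of 4-bromophenyl on a carbonyl carbon). For the measured compounds named here, no measured step swaps 4-bromophenyl for 3,5-difluorophenyl; the closest precedents are the exchanges among chloro, bromo and trifluoromethyl, all small. On that basis compound 4 is expected to show a 1.2-fold lower number from compound 3 to compound 4 (0.10 log units; within the scatter), a step not beyond the scatter in either direction. Compound 4 is estimated at 20000 nM in this assay, within 8000 nM to 50000 nM.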

Compound 4, half-maximal inhibitory concentration: 2440 nM
For compound 4 the middle estimate is 8.2-fold (0.91 log units) above the measured one; measured number outside the range, below it.
By their numbers in this assay, from the lowest: compound 4; then compounds 1, 3 and 2 (each within the scatter of the next, the first and the last beyond it).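

In this assay, the aryl group on the amide carbonyl can shift the read-out well beyond the scatter: a 10-fold lower number from compound 3 to compound 4 (1.01 log units; beyond the scatter), a 12-fold lower number from compound 2 to compound 4 (1.08 log units; beyond the scatter) and a 5.2-fold lower number from compound 1 to compound 4 (0.72 log units; beyond the scatter). Exchanges among 4-chlorophenyl, 4-bromophenyl and 4-(trifluoromethyl)phenyl gave no step larger than modest, whereas 3,5-difluorophenyl gives large steps against two of them; this single change alters both the halogen and the substituent count, and the data do not separate the two. Nothing available explains the gain.

On these data alone, whether a single fluoro, a methoxy or an amine on that phenyl ring would hold this level stays open.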